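This account rests on a few compounds, and the source may have more. Where it says the series, first, only, none or still open, it means among the compounds named here.

Measured compounds:

Compound 1 `C=C1C[C@]23C[C@@]1(O)CC[C@@H]2c1cccc(C)c1[C@@H]3Cn1cc(-c2ccc(Br)cc2)nn1`: in a functional assay on HL-60 cells (Homo sapiens) for cytotoxicity, read by MTT assay, with a stated time of 4 days (a lower number here means a stronger inhibitor, a higher number a weaker inhibitor), compound 1 gives > 20000 nM, which is a limit of the assay and not a number.
Compound 2 `Cc1ccc(S(=O)(=O)Oc2ccc3c(c2C)[C@H](Cn2cc(-c4ccc(C(F)(F)F)cc4)nn2)[C@@]24CC(=O)[C@@](C)(CC[C@@H]32)C4)cc1`: in this assay compound 2 gives > 20000 nM, again a limit of the assay.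
Compound 3 `C=C1C[C@]23C[C@@]1(O)CC[C@H]2c1ccc(O)c(C)c1[C@@H]3Cn1cc(-c2ccc(F)cc2)nn1`: in this assay compound 3 gives > 20000 nM, also a limit of the assay.

Compound 2 therefore stands nowhere distinct among the numbers shown: every value in this assay sits at the same limit, as summed up by the limit of > 20000 nM in this assay, at which 3 of the 3 values shown sit, and no compound can be set above or below another.

Compound 4 `Cc1ccc(S(=O)(=O)Oc2ccc3c(c2C)[C@H](Cn2cc(-c4ccc(Cl)cc4)nn2)[C@@]24CC(=O)[C@@](C)(CC[C@@H]32)C4)cc1` is not yet measured. It differs from compound 2 in one place, (chloro in place of trifluoromethyl on an aromatic carbon), a chloro in place of a trifluoromethyl on an aromatic carbon. For the measured compounds named here, no measured pair carries such a change, so no step size can be read off. With nothing in this assay resolved beyond the limit, no step beyond the scatter is expected in either direction.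

Compound 4 is expected to give 30000 nM in this assay, within 10000 nM to 100000 nM, most likely reported again as a limit only; the expected step that the limit leaves unreadable from compound 2 to compound 4 is essentially none.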

Compound 4, half-maximal inhibitory concentration: > 20000 nM
Compound 4: a limit, no number (the forecaster's own chance of this, stated with the estimate: 85%); the middle value is on the limit's open side.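

No step can be read from compound 2 to compound 4, since both results in this assay are limits of the assay and not numbers: the limit of > 20000 nM in this assay, at which 4 of the 4 values shown sit.

The compounds shown leave open how far the change from 4-(trifluoromethyl)phenyl to 4-chlorophenyl shifts cytotoxicity, and whether any compound in this series gives a readable value.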